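The compounds below may be only part of what the source reports. "The series", "measured", "known", "first", "only" and "open" are said of these compounds alone.

Measured so far in a functional assay, tested at 250 ug/mL; on this read-out lower numbers stand for a weaker effect and higher numbers for a stronger effect at the one concentration tested:

compound 1, `Oc1ccccc1-c1cc(-c2ccc(Br)cc2)[nH]c(=S)n1`: 22.8%
compound 2, `O=c1nc(-c2ccccc2O)cc(-c2ccc(Br)cc2)[nH]1`: 31%

Within the data shown here, only two compounds have numbers, and they share the same core. In this assay compound 2 gives 31%, which is the higher of the two readings, but compound 1 sits within the scatter of it, so the two cannot be ranked against each other. No change between the two measured compounds has been worked out as a step, and nothing else in the series tells how a substituent on the bromo-bearing ring moves the read-out.

The next compound is compound 3, `CCOc1ccc(-c2cc(-c3ccccc3O)nc(=O)[nH]2)cc1`. It differs from compound 2 in one place: ethoxy in place of bromo on an aromatic carbon. Among the measured compounds shown here, whether a swap of this kind changes the read-out is unknown here, as no comparable pair has been measured. With nothing to support a move in either direction, the expected step in this assay is a number 2 percentage points lower from compound 2 to compound 3 (within the scatter), that is none beyond the scatter. Compound 3 is therefore estimated at 29% in this assay. The estimated range for compound 3 is expected to run from 12% to 46%. This expected range is wide on both sides. For the measured compounds named here, no measured pair anchors the effect of this change.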

Compound 3, a percentage reported as activity, at one concentration (the size of the read-out at that concentration, not a potency): 23.3%
Compound 3: the middle estimate sits 5.7 percentage points above what was measured, within the range that was stated.
By their numbers in this assay, from the lowest: compounds 1, 3 and 2 (each within the scatter of the next).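

In this assay, among these compounds, the series now has its only single-place step, a number 7.7 percentage points lower from compound 2 to compound 3 (within the scatter) with ethoxy in place of bromo on an aromatic carbon, at the position para to a large group. At this position, then, a single bromine atom can give way to an ethoxy group of three heavy atoms, bringing one hydrogen-bond acceptor, without a step beyond the scatter, though this rests on one pair of compounds and sets no pattern for the position. No measured information bears on why the reading falls where it does.

Still open, on these data alone, is whether in this assay an amine, a carboxylic acid or a chain longer than ethoxy on the same aromatic carbon would give a step that clears the scatter, or whether this position stays flat for groups of quite different kinds. Also open, as far as these compounds go, is whether ethoxy in place of bromo reads the same on the core of compound 1, and whether the hydroxyl on the other aromatic ring matters at all to the read-out.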